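The source may report more compounds than this note shows. Statements on the series, on what has been measured and on what is new or still open speak of the compounds shown alone.

In an ADME assay on HEp-2 cells (Homo sapiens) for cytotoxicity, read by MTT assay, with a stated time of 60 h (on this read-out lower numbers stand for higher toxicity in this test and higher numbers for lower toxicity in this test), compound 1 `Cc1c(Br)cc2c(nc3n2[C@H]2OC[C@@H](OS(C)(=O)=O)[C@H]2OC3)c1Br` gives 15600 nM, compound 2 `Cc1c(Br)cc2c(nc3n2[C@H]2OC[C@@H](O)[C@H]2OC3)c1Br` gives 34300 nM and compound 3 `Cc1ccc(S(=O)(=O)O[C@@H]2CO[C@H]3[C@@H]2OCc2nc4c(Br)c(C)c(Br)cc4n23)cc1` gives 8940 nM. Compound 3 thus sits with compound 1 at the low end of these three numbers, while compound 2, with its free hydroxyl, stands apart through a 3.8-fold lower number from compound 2 to compound 3 (0.58 log units; beyond the scatter) and a 2.2-fold higher number from compound 1 to compound 2 (0.34 log units; beyond the scatter). Compound 4 `Cc1c(Br)cc2c(nc3n2[C@H]2OC[C@@H](OCc4ccccc4)[C@H]2OC3)c1Br` keeps the shared core and alters one group of compound 3: benzyl in place of (4-methylphenyl)sulfonyl on an oxygen on a saturated carbon. Among the measured compounds shown here, no measured step makes this exact swap. The closest guide is a 1.7-fold lower number from compound 1 to compound 3 (0.24 log units; within the scatter), a change of the group on that same oxygen that stayed within the scatter. The expected step is therefore small, with no firm direction: a 1.2-fold higher number from compound 3 to compound 4 (0.09 log units; within the scatter). For compound 4 the estimated value is 11000 nM, with a range of 5000 nM to 26000 nM.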

Compound 4, half-maximal cytotoxic concentration: 25600 nM
Compound 4: middle estimate off by 2.3-fold (0.37 log units), on the low side; the range from low to high includes it.
By their numbers in this assay, from the lowest: compounds 3, 1, 4 and 2 (each within the scatter of the next, the first and the last beyond it).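

In this assay, replacing (4-methylphenyl)sulfonyl with benzyl keeps the six-membered aromatic ring but removes the sulfonyl (a 2.9-fold higher number from compound 3 to compound 4 (0.46 log units; beyond the scatter)), so that ring alone does not bring the low number of compound 3. Benzyl cannot be told apart from the free hydroxyl (a 1.3-fold lower number from compound 2 to compound 4 (0.13 log units; within the scatter)) or from methylsulfonyl (a 1.6-fold higher number from compound 1 to compound 4 (0.22 log units; within the scatter)), as both steps stay within the scatter. No measured evidence explains these results. As far as these compounds go, how an acetyl group or a longer alkyl chain on this oxygen, or an amine in its place, would read remains open.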